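From 3-cyanobenzyl to hexyl at the ring amine

The source may hold more compounds than are shown below. What is called first, only, known or untested is meant among the compounds shown, and "the series" means these compounds.

Three measured compounds share one core and differ only in the group on the saturated chain carbon bound to the amine nitrogen in a ring. In a functional assay on the whole organism for antagonist activity, with Mus musculus as the target (a lower number here means that less compound is needed, a higher number that more compound is needed for the effect), compound 1 `COc1cc(N)c(Cl)cc1NC(=O)C1CCN(Cc2cccc(C#N)c2)CC1` gives only a limit, > 4 mg/kg. Compound 2 `COc1cc(N)c(Cl)cc1NC(=O)C1CCN(Cc2ccc(OCc3ccccc3)cc2)CC1` likewise gives only a limit in this assay, > 4 mg/kg. Compound 3 `COc1cc(N)c(Cl)cc1NC(=O)C1CCN(Cc2ccccc2F)CC1` also gives only a limit in this assay, > 4 mg/kg. Among the measured compounds shown here, compound 1 thus stands without a number of its own, and the one step between measured compounds, a step that the two limits leave unreadable from compound 1 to compound 3, has no readable size, since all three values sit at the same limit (the limit of > 4 mg/kg in this assay, at which 3 of the 3 values shown sit).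

Compound 4 `CCCCCCN1CCC(C(=O)Nc2cc(Cl)c(N)cc2OC)CC1` differs from compound 1 by pentyl in place of 3-cyanophenyl on a saturated chain carbon bound to an amine nitrogen in a ring. For the measured compounds named here, no measured step of readable size bears on this change, so nothing supports an expected step in this assay in either direction beyond the scatter; the step that the limit leaves unreadable from compound 1 to compound 4 is expected to stay close to where compound 1 sits. Compound 4 is therefore expected to give about 6 mg/kg in this assay, within 1.5 mg/kg to 25 mg/kg, most probably again as a limit only.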

Compound 4, dose for half-maximal effect: > 10 mg/kg
Compound 4: no number, only a limit (the forecaster's own chance of this, stated with the estimate: 75%); at least 1.6-fold (0.22 log units) between middle value and limit.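

In this assay compound 4 gives only a limit, > 10 mg/kg. The steps to compound 4 from compound 1 and from compound 3 cannot be read, with limits on both sides. The compounds shown leave open whether any group at this place gives an actual number in this assay.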